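Amide nitrogen substituents on the shared core

The source may hold more compounds than are shown below. What is called first, only, known or untested is meant among the compounds shown, and "the series" means these compounds.

Compound 3 `COc1cccc(OC)c1C(=O)Nc1c[nH]nc1C(=O)NCc1ncccc1C` stands at the edge of what the assay reports. In an ADME assay on MRC5 cells (Homo sapiens) for inhibition, with a stated time of 72 h (a lower number here means that less compound is needed, a higher number that more compound is needed for the effect), compound 3 gives > 50000 nM, which is a limit of the assay and not a number. The two neighbours with numbers sit close to it: compound 1 `COc1cccc(OC)c1C(=O)Nc1c[nH]nc1C(=O)NC1CCCCCC1` gives 42000 nM in this assay and compound 2 `COc1cccc(OC)c1C(=O)Nc1c[nH]nc1C(=O)N[C@H]1CC[C@H](O)CC1` gives 34000 nM. The measured steps all stay within the scatter: a 1.2-fold lower number from compound 1 to compound 2 (0.09 log units; within the scatter), an at least 1.1-fold higher number from compound 1 to compound 3 (0.07 log units; that floor lies within the scatter) and an at least 1.4-fold higher number from compound 2 to compound 3 (0.16 log units; that floor lies within the scatter). For the measured compounds named here, the only evidence on these steps is the limit of > 50000 nM in this assay, at which 1 of the 3 values shown sits.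

Compound 4 `COc1cccc(OC)c1C(=O)Nc1c[nH]nc1C(=O)Nc1ccccc1` differs from compound 3 by phenyl in place of (3-methylpyridin-2-yl)methyl on an amide-type nitrogen. No measured step exchanges an aromatic group for phenyl on an amide-type nitrogen, so the expectation rests on the three steps shown, none of which moves beyond the scatter. In this assay compound 4 is therefore expected to give about 50000 nM, within a range from 20000 nM to 120000 nM. This estimate means a step of a number no higher from compound 3 to compound 4 (the limit leaves the size open), which is expected to stay within the scatter.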

Compound 4, half-maximal effective concentration: > 50000 nM
Compound 4 ended at the assay's limit (the forecaster's own chance of this, stated with the estimate: 55%); the middle value lies on the limit itself.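

Phenyl, with its ring directly on the amide-type nitrogen, gives no readable number at this position: in this assay compound 4 gives > 50000 nM, which is a limit of the assay and not a number. Against the saturated rings the change reads as an at least 1.4-fold higher number from compound 2 to compound 4 (0.16 log units; that floor lies within the scatter) and an at least 1.1-fold higher number from compound 1 to compound 4 (0.07 log units; that floor lies within the scatter), so these floors do not set phenyl apart from 4-hydroxycyclohexyl or cycloheptyl. The step between the two compounds at the limit cannot be read, and the reading of this position now rests increasingly on: the limit of > 50000 nM in this assay, at which 2 of the 4 values shown sit.

No step shown at this nitrogen goes beyond the scatter, so it stays open whether any substituent here moves the number clearly. A group of another kind in this place, such as a basic amine or a carboxylic acid on a longer chain, remains untested among the compounds shown.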